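Phenyl to 4-bromophenyl on compound 3

The compounds below may be only part of what the source reports. "The series", "measured", "known", "first", "only" and "open" are said of these compounds alone.

In a functional assay on K562 cells (Homo sapiens) for cytotoxicity, read by trypan blue exclusion, with a stated time of 96 h (on this read-out higher numbers stand for weaker inhibition and lower numbers for stronger inhibition), compound 1 `COc1ccc(NS(=O)(=O)/C=C/c2c(OC)cc(OC)cc2OC)cc1` gives 75 nM and compound 2 `COc1cc(OC)c(/C=C/S(=O)(=O)Nc2ccc(OC)c(F)c2)c(OC)c1` gives 75 nM. Compound 3 `COC(=O)C(Nc1cc(NS(=O)(=O)/C=C/c2c(OC)cc(OC)cc2OC)ccc1OC)c1ccccc1` stands highest of the three numbers at 2500 nM, which makes it the weakest inhibitor measured so far. Both steps leading to it are large: a 33-fold higher number from compound 1 to compound 3 (1.52 log units; beyond the scatter), and a 33-fold higher number from compound 2 to compound 3 (1.52 log units; beyond the scatter).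

Compound 4 `COC(=O)C(Nc1cc(NS(=O)(=O)/C=C/c2c(OC)cc(OC)cc2OC)ccc1OC)c1ccc(Br)cc1` carries a single change: bromo in place of hydrogen on an aromatic carbon. This is bromo in place of hydrogen on an aromatic carbon, para to a large group, turning phenyl into 4-bromophenyl.

The closest measured change is fluoro in place of hydrogen on an aromatic carbon, which gave no change at the digits printed from compound 1 to compound 2 (within the scatter). That step lies outside the phenyl in question, so it is only a loose guide. For the measured compounds named here, the two large steps introduce the entire group that carries this phenyl, and no measured compound varies the phenyl itself. Going by the values given here, the data therefore offer no support for a shift of any particular size, and only one small precedent for leaving the number in place.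

No step beyond the scatter is expected in this assay, and the expected step is a 1.3-fold lower number from compound 3 to compound 4 (0.10 log units; within the scatter). The margin stays wide on so little evidence. Compound 4 is estimated at 2000 nM, with an expected range of 700 nM to 6000 nM.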

Compound 4, half-maximal inhibitory concentration: 1000 nM
Beside the measured number, compound 4's estimate is 2.0-fold (0.30 log units) above it, and the stated range covers the measured number.
By their numbers in this assay, from the lowest: compounds 1 and 2 (each within the scatter of the next); then compound 4; then compound 3.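

Phenyl to 4-bromophenyl gives a 2.5-fold lower number from compound 3 to compound 4 (0.40 log units; beyond the scatter) in this assay, which shows that a single bromo on an aromatic carbon, para to a large group, moves the number beyond the scatter and that this phenyl is not silent to substitution. The other single-atom step, no change at the digits printed from compound 1 to compound 2 (within the scatter), stayed within the scatter, but it differs in both the atom and the place, so the pair gives no halogen trend. The new step is also modest beside a 33-fold higher number from compound 1 to compound 3 (1.52 log units; beyond the scatter), so bromo on this phenyl offsets only a small part of the large step that came with the whole group, and no measurement on hand bears on why the number moved.

Still open, going by these compounds, is whether the step follows bromine itself or any group at this place, a question that chloro, methoxy or an amine on the same aromatic carbon would help to settle. Also open, on these data alone, is what the rest of the added group contributes, which a carboxylic acid in place of the methoxycarbonyl or a longer chain on the ester would begin to separate from the role of the phenyl.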